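Swapping Dichloro for Dihydroxy on a Curcumin-like Scaffold

The source may report more compounds than this note shows. Statements on the series, on what has been measured and on what is new or still open speak of the compounds shown alone.

Measured compounds:
Compound 1, `COc1cccc(/C=C2\CCC/C(=C\c3ccc(OC)c(OC)c3)C2=O)c1`: 4600 nM
Compound 2, `COc1ccc(/C=C2\CCC/C(=C\c3cccc(O)c3)C2=O)cc1OC`: 2900 nM
Compound 3, `COc1ccc(/C=C2\CCC/C(=C\c3ccc(Cl)c(Cl)c3)C2=O)cc1OC`: 4400 nM

In a functional assay on MCF7 cells (Homo sapiens) for cytotoxicity, read by MTT assay, with a stated time of 72 h (on this read-out lower numbers stand for stronger inhibition and higher numbers for weaker inhibition), compound 3 gives 4400 nM. Among the three measured numbers compound 3 stands second highest; its nearest neighbour is compound 1 and its furthest is compound 2, yet both of those gaps are within the scatter, so no ordering among the three can be claimed.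

The next compound, compound 4, `COc1ccc(/C=C2\CCC/C(=C\c3ccc(O)c(O)c3)C2=O)cc1OC`, keeps the core of compound 3 and differs in one place: 3,4-dihydroxyphenyl in place of 3,4-dichlorophenyl on a double-bonded chain carbon bound to a double-bonded ring carbon

Among the compounds with values here, two measured steps bear on this change. Replacing a methyl with hydrogen on an aromatic oxygen gave a 1.6-fold lower number from compound 1 to compound 2 (0.20 log units; within the scatter). Putting 3,4-dichlorophenyl in place of 3-hydroxyphenyl gave a 1.5-fold higher number from compound 2 to compound 3 (0.18 log units; within the scatter). Both lie within the scatter, so adding hydroxyl groups or removing chlorines here has not moved the read-out beyond noise. For compound 4 no step beyond the scatter is therefore expected, with at most a slight lean toward a lower number, expected as a 1.3-fold lower number from compound 3 to compound 4 (0.11 log units; within the scatter). Compound 4 is expected to give 3400 nM, in the range 1500 nM to 8000 nM.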

Compound 4, half-maximal inhibitory concentration: 14400 nM
Compound 4: middle estimate off by 4.2-fold (0.63 log units), on the low side; the whole stated range lies below it.
By their numbers in this assay, from the lowest: compounds 2, 3 and 1 (each within the scatter of the next); then compound 4.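

In this assay, within the data shown here, 3,4-dihydroxyphenyl in place of 3,4-dichlorophenyl gives a 3.3-fold higher number from compound 3 to compound 4 (0.51 log units; beyond the scatter) and so is the first change on this double-bonded chain carbon to pass the scatter. Adding one hydroxy on an aromatic carbon is enough, as a 5.0-fold higher number from compound 2 to compound 4 (0.70 log units; beyond the scatter) shows, so 3-hydroxyphenyl and 3,4-dihydroxyphenyl do not read alike here. Starting from 3-methoxyphenyl gives the same picture with a 3.1-fold higher number from compound 1 to compound 4 (0.50 log units; beyond the scatter) and leaves 3,4-dihydroxyphenyl as the one group here set apart from the others, which remain within the scatter of each other.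

From the compounds shown here alone, how an amine or a carboxylic acid on that ring would read at this place stays open. The data shown offer no measured explanation for the step.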